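This account rests on a few compounds, and the source may have more. Where it says the series, first, only, none or still open, it means among the compounds named here.

Of the compounds shown here, two have been measured in an assay on isolated protein with Bile acid receptor (Homo sapiens) as the target; a higher number here means that more compound is needed for the effect, a lower number that less compound is needed. Compound 1, `COC(=O)/C=C/c1cccc(N(Cc2ccc(/C=C/c3ccccn3)cc2)C(=O)C(C)C)c1`, carries a pyridine-bearing styryl arm and an isobutyryl amide; in this assay compound 1 gives 310 nM. Compound 2, `COC(=O)/C=C/c1cccc(N(Cc2ccc(-c3ccc(F)c(Cl)c3)cc2)C(=O)C2CCCCC2)c1`, instead carries a 3-chloro-4-fluorophenyl ring directly on the benzyl group and a cyclohexanecarbonyl amide; in this assay compound 2 gives 66 nM. Compound 2 therefore has the lower of the two numbers, and its gap to compound 1 lies beyond the usual scatter. Compounds 1 and 2 differ in more than one place. No single part of that gap can be assigned to either change.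

Compound 3, `COC(=O)/C=C/c1cccc(N(Cc2ccc(-c3ccc(SC)cc3)cc2)C(=O)C2CCCCC2)c1`, keeps the shared core and the cyclohexanecarbonyl amide of compound 2 and changes only the outer ring: 4-(methylsulfanyl)phenyl in place of 3-chloro-4-fluorophenyl on an aromatic carbon. The biaryl arrangement itself is kept; one ring of the same size replaces another. Within the data shown here, no measured pair in this set isolates such a swap, so the expectation rests on compound 2 alone. The step from compound 2 to compound 3 is expected to be small, a 1.5-fold higher number from compound 2 to compound 3 (0.18 log units; within the scatter), close to or within the scatter. Compound 3 is estimated at 100 nM, with a range from 35 nM to 300 nM.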

Compound 3, half-maximal effective concentration: 69 nM
For compound 3 the middle estimate is 1.4-fold (0.16 log units) above the measured one; low and high end bracket the measured number.
By their numbers in this assay, from the lowest: compounds 2 and 3 (each within the scatter of the next); then compound 1.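

Among these compounds, compounds 1 and 2 differ in more than one place, so this is the first change here that can be read on its own: in this assay, 4-(methylsulfanyl)phenyl in place of 3-chloro-4-fluorophenyl gives a 1.0-fold higher number from compound 2 to compound 3 (0.02 log units; within the scatter). At this position, on an aromatic carbon and para to a large group, the fluorine and chlorine of the outer ring can therefore be exchanged for a sulfur-bearing group without a change beyond the scatter, at least for this one pair on the cyclohexanecarbonyl amide background. No measurement bears on why the two outer rings give readings so close together.

Going by these compounds, a single swap cannot show how far this tolerance extends, so it remains open whether an outer ring carrying an amine or a carboxylic acid would read the same way as these two rings. Also open, on these data alone, is how much of the gap to compound 1 belongs to the cyclohexanecarbonyl amide alone and how much to the arm on the benzyl group.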